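Capping the amine of compound 1: cytotoxicity notes

A few compounds are considered here, and "the series" means these few. Any claim that something is new, unique, unknown or untested is made for them only; others in the source may bear on it.

Measured in a functional assay on MCF7 cells (Homo sapiens) for cytotoxicity, read by MTT assay, with a stated time of 72 h; a higher number here means a weaker inhibitor, a lower number a stronger inhibitor:
compound 1 `COc1ccc(/C(=C(/CCN)c2ccccc2)c2ccccc2)cc1`: 16900 nM
compound 2 `COc1ccc(/C(=C(/CCNC(=O)NC2CCCCC2)c2ccccc2)c2ccccc2)cc1`: 37200 nM
compound 3 `COc1ccc(/C(=C(/CCNC(=O)N2CCOCC2)c2ccccc2)c2ccccc2)cc1`: > 50000 nM, a limit of the assay and not a number

Compound 1 gives the lowest of the two numbers; compound 2 is nearest, with a 2.2-fold higher number from compound 1 to compound 2 (0.34 log units; beyond the scatter). Compound 3 reaches only (the limit of > 50000 nM in this assay, at which 1 of the 3 values shown sits), so its step of an at least 2.9-fold higher number from compound 1 to compound 3 (0.47 log units; beyond the scatter) is a floor. Between the two capped compounds, an at least 1.3-fold higher number from compound 2 to compound 3 (0.12 log units; that floor lies within the scatter).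

Compound 4 `COc1ccc(/C(=C(/CCNC(=O)C(=O)N2CCCC2)c2ccccc2)c2ccccc2)cc1` is not yet measured. It differs from compound 1 by ((pyrrolidin-1-yl)carbonyl)carbonyl in place of hydrogen on an amine nitrogen. Both measured cappings of this amine nitrogen raised the number, one of them to the limit, so in this assay a modest rise beyond the scatter is expected for compound 4, with a real chance of another limit. Compound 4 is expected near 40000 nM, between 18000 nM and 90000 nM. The expected step is a 2.4-fold higher number from compound 1 to compound 4 (0.37 log units; beyond the scatter).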

Compound 4, half-maximal inhibitory concentration: > 50000 nM
Compound 4: a limit, no number (the forecaster's own chance of this, stated with the estimate: 40%); middle value at least 1.2-fold (0.09 log units) away from the limit.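

In this assay compound 4 gives > 50000 nM, a limit and not a number. All three cappings of this amine nitrogen now raise the number, the ((pyrrolidin-1-yl)carbonyl)carbonyl cap with an at least 2.9-fold higher number from compound 1 to compound 4 (0.47 log units; beyond the scatter), so the rise is not confined to the cyclohexylcarbamoyl and (morpholin-4-yl)carbonyl caps. The capped compounds stay unordered, with an at least 1.3-fold higher number from compound 2 to compound 4 (0.12 log units; that floor lies within the scatter). The step from compound 3 to compound 4 is unreadable, and the ceiling is now shared: the limit of > 50000 nM in this assay, at which 2 of the 4 values shown sit.

Open, as far as these compounds go, is whether a smaller acetyl or methyl group on this amine nitrogen, or a longer chain carrying the free amine, would hold the number of compound 1 at 16900 nM.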